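A few compounds are considered here, and "the series" means these few. Any claim that something is new, unique, unknown or untested is made for them only; others in the source may bear on it.

Three compounds built on one shared core differ only in the amine attached to a saturated chain carbon bound to an aromatic carbon. In an assay on isolated protein for inhibition of Maltase-glucoamylase (Homo sapiens), with stated times of 15 min and 10 min, tested at 64 uM (on this read-out lower numbers stand for less inhibition and higher numbers for more inhibition at the one concentration tested (going by the name of the read-out)), compound 1 `C=CCc1ccc(O)c(-c2cc(CC=C)cc(CN(CC(C)C)CC(C)C)c2O)c1` gives 3.8%, compound 2 `C=CCc1ccc(O)c(-c2cc(CC=C)cc(CN(CCC)CCC)c2O)c1` gives 6.3%, and compound 3 `C=CCc1ccc(O)c(-c2cc(CC=C)cc(CN3CCC(C)CC3)c2O)c1` gives 6.3%. Compound 2 stands level with compound 3 at the digits shown, and the two together are the highest of the three numbers, but every gap here lies within the scatter, so none of the three numbers can be called higher than another. The steps read a number 2.5 percentage points higher from compound 1 to compound 2 (within the scatter), a number 2.5 percentage points higher from compound 1 to compound 3 (within the scatter) and no change at the digits printed from compound 2 to compound 3 (within the scatter).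

Compound 4 `C=CCc1ccc(O)c(-c2cc(CC=C)cc(CN(C)c3ccccc3)c2O)c1` has not yet been measured. It differs from compound 2 by methyl(phenyl)amino in place of dipropylamino on a saturated chain carbon bound to an aromatic carbon. This is a third swap of the amine at the same place, and the earlier two bear on it directly. Because a number 2.5 percentage points higher from compound 1 to compound 2 (within the scatter) and no change at the digits printed from compound 2 to compound 3 (within the scatter) both stayed within the scatter, the expected step from compound 2 to compound 4 is also one within the scatter, with no clear direction, which in numbers means a number 0.3 percentage points lower from compound 2 to compound 4 (within the scatter). Compound 4 is therefore estimated at 6%, in a range from 0% to 16%.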

Compound 4, a percentage reported as inhibition, at one concentration (the size of the read-out at that concentration, not a potency): 15.5%
Beside the measured number, compound 4's estimate is 9.5 percentage points below it; the range from low to high includes it.
By their numbers in this assay, from the lowest: compounds 1, 2, 3 and 4 (each within the scatter of the next, the first and the last beyond it).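

Within the data shown here, the swap to methyl(phenyl)amino gives the first step at this place to pass the scatter: in this assay the amine change shows a number 11.7 percentage points higher from compound 1 to compound 4 (beyond the scatter) and that step is modest. Compound 4 is still not separated from the other two amines, with a number 9.2 percentage points higher from compound 2 to compound 4 (within the scatter) and a number 9.2 percentage points higher from compound 3 to compound 4 (within the scatter) as well, so it stands clear of compound 1 alone. No measurement given here explains this step.

On these data alone, it stays open whether the six-membered aromatic ring or the methyl on the nitrogen carries the step, and a benzylamino or a diphenylamino group at this place would bear on that. As far as these compounds go, a reading at a single concentration also gives no potency, so how these amines rank by potency remains unknown.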